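A few compounds are considered here, and "the series" means these few. Any claim that something is new, unique, unknown or untested is made for them only; others in the source may bear on it.

Measured compounds in a functional assay on A549 cells (Homo sapiens) for antiproliferative activity, read by MTT assay, with a stated time of 48 h; a higher number here means a weaker inhibitor, a lower number a stronger inhibitor:

Compound 1 `CCn1cc(-c2nc3ccc([N+](=O)[O-])cc3o2)c(=O)c2cc(F)c(N3CCNC(C)C3)c(F)c21` gives 1470 nM.
Compound 2 `CCn1cc(-c2ccc(Cl)cc2)c(=O)c2cc(F)c(N3CCNCC3)cc21` gives 1250 nM.
Compound 3 `CCn1cc(-c2ccc(OC)cc2)c(=O)c2cc(F)c(N3CCNCC3)cc21` gives 11600 nM.

Compound 2 has the lowest number of the three in this assay, though its gap to compound 1 is within the scatter; its gap to compound 3 is beyond it, shown by a 9.3-fold higher number from compound 2 to compound 3 (0.97 log units; beyond the scatter). Compound 4 `CCn1cc(-c2cccc(F)c2)c(=O)c2cc(F)c(N3CCNCC3)cc21` has not yet been measured. Its difference from compound 2: 3-fluorophenyl in place of 4-chlorophenyl on an aromatic carbon.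

Within the data shown here, no measured step matches this change. Among the measured compounds shown here, the only step on the same aromatic carbon, a 9.3-fold higher number from compound 2 to compound 3 (0.97 log units; beyond the scatter), replaces chloro with methoxy and gives a modest weakening. For the measured compounds named here, compound 4 keeps a halogen but a different one at a different position on the phenyl, and no measured pair tests either of those moves alone. The step from compound 2 to compound 3 suggests the aryl group matters, so a loss of some size is expected, but smaller than that step. Compound 4 is expected to give 2500 nM in this assay, between 900 nM and 7000 nM, an expected step of a 2.0-fold higher number from compound 2 to compound 4 (0.30 log units; within the scatter).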

Compound 4, half-maximal inhibitory concentration: 3060 nM
Compound 4: the middle estimate sits 1.2-fold (0.09 log units) below what was measured; low and high end bracket the measured number.
By their numbers in this assay, from the lowest: compounds 2 and 1 (each within the scatter of the next); then compound 4; then compound 3.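

In this assay, the aryl position on the shared core now carries three groups that separate beyond the scatter: a 2.4-fold higher number from compound 2 to compound 4 (0.39 log units; beyond the scatter), while a 3.8-fold lower number from compound 3 to compound 4 (0.58 log units; beyond the scatter). A phenyl with a halogen is therefore not tied to a single reading here, and 3-fluorophenyl falls on the weaker side of 4-chlorophenyl but on the stronger side of 4-methoxyphenyl, although the step from 4-chlorophenyl changes both the halogen and its place on the phenyl. No data shown explain this order.

A 4-fluorophenyl or 3-chlorophenyl analogue would separate the effect of the halogen from that of its place on the phenyl. As far as these compounds go, how an amine or a carboxylic acid on this phenyl would read also remains open.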